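Removing a Methoxy Group: From Compound 3 to Compound 4

A few compounds are considered here, and "the series" means these few. Any claim that something is new, unique, unknown or untested is made for them only; others in the source may bear on it.

Three compounds have been measured in an assay on CHO cells for displacement of a labelled ligand from Substance-P receptor (Homo sapiens); on this read-out higher numbers stand for weaker inhibition and lower numbers for stronger inhibition:

Compound 1 (`COc1ccc(C(F)(F)F)cc1[C@H]1COCC2(C1)OCCN[C@H]2c1ccc(F)cc1`): 1.3 nM
Compound 2 (`Fc1ccc([C@@H]2NCCOC23COC[C@H](c2cccc(C(F)(F)F)c2)C3)cc1`): 30 nM
Compound 3 (`COc1ccc(OC)c([C@H]2COCC3(C2)OCCN[C@H]3c2ccc(F)cc2)c1`): 16 nM

The step of a 23-fold higher number from compound 1 to compound 2 (1.36 log units; beyond the scatter) comes from one change, (hydrogen in place of methoxy on an aromatic carbon). The step of a 12-fold higher number from compound 1 to compound 3 (1.09 log units; beyond the scatter) comes from methoxy in place of trifluoromethyl on an aromatic carbon, and this is also how the core of compound 3 differs from the core of compound 1. Compound 4 (`COc1ccccc1[C@H]1COCC2(C1)OCCN[C@H]2c1ccc(F)cc1`) has not been measured; it differs from compound 3 by hydrogen in place of methoxy on an aromatic carbon. Among the compounds with values here, this is the same kind of change as the one from compound 1 to compound 2, but not the same: there the place was ortho to a large group and para to a trifluoromethyl group, here it is meta to a large group and para to a methoxy group.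

In this assay compound 4 is expected to show a 5.0-fold higher number from compound 3 to compound 4 (0.70 log units; beyond the scatter), a smaller step than the earlier one. This expectation rests on the step of a 23-fold higher number from compound 1 to compound 2 (1.36 log units; beyond the scatter) together with the different surroundings of the place. Compound 4 is estimated at 80 nM, expected to lie between 25 nM and 300 nM.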

Compound 4, half-maximal inhibitory concentration: 13 nM
Compound 4: the middle estimate sits 6.2-fold (0.79 log units) above what was measured; measured number outside the range, below it.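

In this assay, hydrogen in place of methoxy gives a 1.2-fold lower number from compound 3 to compound 4 (0.09 log units; within the scatter), whereas on the same core hydrogen in place of trifluoromethyl gives a 10-fold higher number from compound 1 to compound 4 (1.00 log units; beyond the scatter). The removal of a methoxy group therefore does not carry over as one fixed step from one core to another in this series: the same change on two cores in this assay, a 23-fold higher number (1.36 log units; beyond the scatter) from compound 1 to compound 2 and a 1.2-fold lower number (0.09 log units; within the scatter) from compound 3 to compound 4, 28-fold (1.45 log units) apart, beyond the scatter of two such steps This shows that the same kind of change can matter greatly in one setting and be undetectable in another, but it does not show which difference between the two settings is responsible, and two pairs of compounds make no general rule for the series.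

The compounds shown leave open how other groups at the place of the removed methoxy, such as a chlorine atom, an ethoxy group or an amine, would read in this assay. Also open, as far as these compounds go, is whether a nitrile or a methyl group could stand in for the trifluoromethyl group of compound 1.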